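This account rests on a few compounds, and the source may have more. Where it says the series, first, only, none or still open, it means among the compounds named here.

In an ADME assay on MRC5 cells (Homo sapiens) for cytotoxicity, read by neutral red uptake, with a stated time of 24 h (on this read-out lower numbers stand for stronger inhibition and higher numbers for weaker inhibition), compound 1 (`CCC(=O)Oc1c(C(C)C)cc2c3c1OC(=O)[C@@]31CCCC(C)(C)[C@@H]1CC2`) gives 125000 nM. Compound 2 (`CCCCCCCCCCCC(=O)Oc1c(C(C)C)cc2c3c1OC(=O)[C@@]31CCCC(C)(C)[C@@H]1CC2`) gives > 1000000 nM, which is a limit of the assay and not a number. Compound 2 therefore stands at the limit of > 1000000 nM in this assay, at which 1 of the 2 values shown sits.

The change to compound 3 (`CCCCC/C=C/C/C=C/CCCCCCCC(=O)Oc1c(C(C)C)cc2c3c1OC(=O)[C@@]31CCCC(C)(C)[C@@H]1CC2`) lies in the ester chain: deca-1,4-dien-1-yl in place of butyl on a saturated chain carbon, seven bonds along the chain from a carbonyl carbon. Going by the values given here, the one measured step that bears on this is an at least 8.0-fold higher number from compound 1 to compound 2 (0.90 log units; beyond the scatter). From the compounds shown here alone, that step also extends the chain, but it ends at a limit, so its full size remains open. Among the compounds with values here, no measured compound carries double bonds in the chain. In this assay, no step beyond the scatter is therefore expected, and the reading should stay at the high end, quite possibly as a limit again. The estimated change is a number no higher from compound 2 to compound 3 (the limit leaves the size open). For compound 3 the expected value is 1000000 nM, with an estimated range of 400000 nM to 2500000 nM.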

Compound 3, half-maximal inhibitory concentration: 293000 nM
Estimate against measurement, compound 3: 3.4-fold (0.53 log units) above, and the stated range ends above it.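

There is an at least 3.4-fold lower number from compound 2 to compound 3 (0.53 log units; beyond the scatter) in this assay when deca-1,4-dien-1-yl replaces butyl, seven bonds along the chain from a carbonyl carbon, so at this position a longer ester chain does not by itself keep the number high. That direction is the reverse of an at least 8.0-fold higher number from compound 1 to compound 2 (0.90 log units; beyond the scatter) in the earlier extension, and compound 3 goes against any rise of the number with chain length. Compound 2 stands at a limit of the assay and not at a number, so the full size of the new step stays open: the limit of > 1000000 nM in this assay, at which 1 of the 3 values shown sits.

From the compounds shown here alone, the double bonds and the added chain length change together in compound 3, and their separate shares stay open. How a fully saturated chain of the same length, or a chain bearing a carboxylic acid, would read is open too.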